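A few compounds are considered here, and "the series" means these few. Any claim that something is new, unique, unknown or untested is made for them only; others in the source may bear on it.

In a functional assay on DWD cells (Homo sapiens) for inhibition, read by sulforhodamine B assay (a higher number here means a weaker inhibitor of growth, a lower number a stronger inhibitor of growth), three compounds that share one core have been measured. Compound 1 `c1ccc(-c2ccc(-c3ccc(-c4nc5ccccc5[nH]4)cc3)cc2)cc1` gives 100000 nM, compound 2 `FC(F)(F)c1ccc(-c2ccc(-c3ccc(-c4nc5ccccc5[nH]4)cc3)cc2)cc1` gives 100000 nM, and compound 3 `CN(C)c1ccc(-c2ccc(-c3ccc(-c4nc5ccccc5[nH]4)cc3)cc2)cc1` gives 100000 nM. Compound 3 therefore stands level with the other two, and none of the three can be ranked above another.

The next compound to consider is compound 4 `Clc1cccc(-c2ccc(-c3ccc(-c4nc5ccccc5[nH]4)cc3)cc2)c1`. It has 3-chlorophenyl in place of 4-(dimethylamino)phenyl, on an aromatic carbon para to a large group: 3-chlorophenyl in place of 4-(dimethylamino)phenyl on an aromatic carbon.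

Going by the values given here, three measured steps bear on this change. Trifluoromethyl in place of hydrogen gave no change at the digits printed from compound 1 to compound 2 (within the scatter). Dimethylamino in place of hydrogen gave no change at the digits printed from compound 1 to compound 3 (within the scatter). Dimethylamino in place of trifluoromethyl gave no change at the digits printed from compound 2 to compound 3 (within the scatter). None of these steps goes beyond the scatter, so exchanging one group for another on this core has not yet moved the reading at all. Among the compounds with values here, the evidence is only indirect, since none of the measured compounds contains chlorine.

No step beyond the scatter is therefore expected, in either direction, and the expected step is no change at the digits printed from compound 3 to compound 4 (within the scatter). Compound 4 is estimated at 100000 nM, with an expected range from 40000 nM to 100000 nM.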

Compound 4, concentration for 50% growth inhibition: 100000 nM
Beside the measured number, compound 4's estimate shows no gap at the digits printed, and the stated range covers the measured number.
By their numbers in this assay, from the lowest: compounds 1, 2, 3 and 4 (each within the scatter of the next).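

In this assay, swapping the whole outer group for 3-chlorophenyl leaves the reading unmoved, with no change at the digits printed from compound 3 to compound 4 (within the scatter) and likewise no change at the digits printed from compound 2 to compound 4 (within the scatter) when the group replaced is 4-(trifluoromethyl)phenyl. Measured against the plain parent, chloro in place of hydrogen gives no change at the digits printed from compound 1 to compound 4 (within the scatter), so a chlorine atom now joins trifluoromethyl and dimethylamino among the groups that leave the reading where it stood, and this holds for a group named with a 3 as well as for those named with a 4. Nothing in the data on hand accounts for this flat result.

With all four compounds level, the compounds shown do not reveal whether any change on the shared core can shift growth inhibition in this assay, or which part of the molecule would matter if one did. Still open, going by these compounds, is how the reading responds to a primary amine, a carboxylic acid or a longer alkyl chain on that same aromatic carbon, and to changes made elsewhere on the core.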